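The compounds below may be only part of what the source reports. "The series", "measured", "known", "first", "only" and "open" are said of these compounds alone.

In an assay on HL-60 cells for agonist activity at vitamin D3 receptor (Homo sapiens), read by microscopy, with a stated time of 96 h (on this read-out higher numbers stand for an effect only at larger amounts of compound and lower numbers for an effect already at smaller amounts), compound 1 `CCn1c(C(=O)N(C)CC(=O)O)ccc1C(CC)(CC)c1ccc(OCC(O)C(C)(C)C)c(C)c1` gives 740 nM. Compound 2 `CCn1c(C(=O)OCc2ccccn2)ccc1C(CC)(CC)c1ccc(OCC(=O)C(C)(C)C)c(C)c1` gives only a limit of this assay, reported as > 50000 nM, so no number is known for it (the limit of > 50000 nM in this assay, at which 1 of the 2 values shown sits). Compound 3 `CCn1c(C(=O)OCc2ccccn2)ccc1C(CC)(CC)c1ccc(OCC(O)C(C)(C)C)c(C)c1` differs from compound 2 in one place: 1-hydroxy-2,2-dimethylpropyl in place of (tert-butyl)carbonyl on a saturated chain carbon bound to an oxygen on an aromatic ring. Compound 1, with its 740 nM in this assay, carries the same hydroxyl group, so a step toward activity at smaller amounts is expected, estimated as an at least 16-fold lower number from compound 2 to compound 3 (1.22 log units; beyond the scatter). Compound 3 is thus expected to give about 3000 nM, somewhere between 300 nM and 50000 nM.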

Compound 3, half-maximal effective concentration: > 50000 nM
Compound 3 gave a limit, no number (the forecaster's own chance of this, stated with the estimate: 25%); at least 16-fold (1.22 log units) between middle value and limit.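

With (pyridin-2-yl)methoxy on the carbonyl carbon, placing 1-hydroxy-2,2-dimethylpropyl where (tert-butyl)carbonyl stood does not bring compound 3 off the limit of this assay, so this change alone yields no measurable value. The step between compound 2 and compound 3 cannot be read: the limit of > 50000 nM in this assay, at which 2 of the 3 values shown sit.
The other site shows a readable change, with (pyridin-2-yl)methoxy in place of (carboxymethyl)(methyl)amino on a carbonyl carbon giving an at least 67-fold higher number from compound 1 to compound 3 (1.82 log units; beyond the scatter).

On these data alone, whether the hydroxyl change matters when (carboxymethyl)(methyl)amino sits on that carbonyl carbon remains open. So does the effect of a smaller group there, such as methylamino.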